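Trimming the Saturated Ring of a Chloro-Substituted Core

The compounds below may be only part of what the source reports. "The series", "measured", "known", "first", "only" and "open" are said of these compounds alone.

Compound 2 `O=C(Nc1cc2cc[nH]c(=O)c2cc1Cl)[C@@H]1CCCNC1` gives 47 nM in an assay on isolated protein for inhibition of Rho-associated protein kinase 2 (Homo sapiens), read by a luciferase reporter (a higher number here means a weaker inhibitor, a lower number a stronger inhibitor), the highest number among the three measured, so it is the weakest inhibitor of the set. Among the measured compounds shown here, compound 1 `O=C(Nc1cc2cc[nH]c(=O)c2cc1Cl)C1CNCC1c1ccccn1` gives 14 nM and compound 3 `O=C(Nc1cc2cc[nH]c(=O)c2cc1Cl)C1CNCC1c1cccc(C(F)(F)F)c1` gives 4 nM; the only measured step, a 3.5-fold lower number from compound 1 to compound 3 (0.54 log units; beyond the scatter), concerns the group on a saturated ring carbon and leaves the ring itself unchanged. Compound 4 `NCC(=O)Nc1cc2cc[nH]c(=O)c2cc1Cl` differs from compound 2 by aminomethyl in place of piperidin-3-yl on a carbonyl carbon. For the measured compounds named here, no measured step covers such a truncation; the values of compounds 1, 2 and 3 show only how the larger ring-bearing amides fare. A weakening is expected, the step of an 8.5-fold higher number from compound 2 to compound 4 (0.93 log units; beyond the scatter) resting on the loss of the ring alone. Compound 4 is therefore estimated at 400 nM, within 80 nM to 2000 nM.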

Compound 4, half-maximal inhibitory concentration: 120 nM
The estimate for compound 4 lay 3.3-fold (0.52 log units) above the measured number; the measured number falls inside the stated range.
By their numbers in this assay, from the lowest: compound 3; then compound 1; then compound 2; then compound 4.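

In this assay, the step at this carbonyl carbon is a 2.6-fold higher number from compound 2 to compound 4 (0.41 log units; beyond the scatter), so the amide keeps much of its inhibition once the ring of piperidin-3-yl and its defined stereocentre are gone. Aminomethyl brings the same count of hydrogen-bond donors and acceptors as the group it replaces, so the change removes ring carbons without altering that count. Nothing available explains the size of this step.

From the compounds shown here alone, it remains open whether a longer chain ending in an amine would recover the lost inhibition. Going by these compounds, the effect of a carboxylic acid in place of the amine of aminomethyl is also open.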